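Ethoxy for fluoro on the aryl ring of compound 1

The compounds below may be only part of what the source reports. "The series", "measured", "known", "first", "only" and "open" are said of these compounds alone.

Working notes on the series. Of the compounds shown here, two have been measured in an assay on cells for inhibition of Palmitoleoyl-protein carboxylesterase NOTUM variant C330S (Homo sapiens), read by fluorescence, with a stated time of 40 min; on this read-out higher numbers stand for weaker inhibition and lower numbers for stronger inhibition. Compound 1 `Cc1cc(C(=O)O)c(C)n1-c1cccc(F)c1` gives 1500 nM in this assay. Compound 2 `Cc1cc(C(=O)O)c(C)n1-c1ccc(F)cc1` gives 1900 nM in this assay. The gap between compound 1 and compound 2 falls within the scatter of repeated measurement, so the two do not separate on the numbers in hand; compound 1 serves as the reference point for the next step.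

Compound 3 `CCOc1cccc(-n2c(C)cc(C(=O)O)c2C)c1` has not yet been measured. Against compound 1 the change is ethoxy in place of fluoro on an aromatic carbon. For the measured compounds named here, no pair among the measured compounds shows this exchange, so its effect cannot be read from the data so far. The step from compound 1 to compound 3 is expected to be a 1.3-fold lower number from compound 1 to compound 3 (0.10 log units; within the scatter), small and of uncertain direction, probably not beyond the scatter. Compound 3 is therefore estimated at 1200 nM in this assay, with a range from 400 nM to 4000 nM.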

Compound 3, half-maximal inhibitory concentration: 640 nM
For compound 3 the middle estimate is 1.9-fold (0.27 log units) above the measured one; measured number inside the range.
By their numbers in this assay, from the lowest: compound 3; then compounds 1 and 2 (each within the scatter of the next).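

In this assay, for the compounds shown here, ethoxy in place of fluoro on this aromatic carbon, meta to a large group, gives a 2.3-fold lower number from compound 1 to compound 3 (0.37 log units; beyond the scatter), the first step that lies beyond the scatter. Compounds 1 and 2 did not separate, so they gave no sign that this position could move the number; compound 3 shows that it can, and that the larger ethoxy group, with 3 heavy atoms against 1 for fluoro, is accepted here with a lower number, not a higher one. This rests on a single exchange, and nothing in hand accounts for the step.

Open, going by these compounds, is whether the oxygen or the chain carries the change, which methoxy, a propoxy chain or an ethyl group at this carbon would separate. Also open, on these data alone, is whether ethoxy on the carbon bearing fluoro in compound 2 would give a similar step.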